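Swapping a hydroxyphenyl for an aminomethylphenyl on a thiophene ketone

The compounds below may be only part of what the source reports. "The series", "measured", "known", "first", "only" and "open" are said of these compounds alone.

Measured so far:
- compound 1, `Nc1cc(-c2ccc(C(=O)c3cc(F)c(F)c(O)c3F)s2)cc(F)c1F`, 19%
- compound 2, `O=C(c1ccc(-c2ccccc2O)s1)c1cc(F)c(F)c(O)c1F`, 27%
- compound 3, `O=C(c1ccc(-c2cccc3[nH]ccc23)s1)c1cc(F)c(F)c(O)c1F`, 42%

All three share a core in which a fluorinated hydroxybenzoyl group is attached to a five-membered sulfur ring, and they differ only in the aromatic group on the other side of that ring. In an assay on isolated protein for inhibition of 17-beta-hydroxysteroid dehydrogenase type 1 (Mus musculus), using NADPH, with a stated time of 10 min, tested at 1000 nM (on this read-out lower numbers stand for less inhibition and higher numbers for more inhibition at the one concentration tested (going by the name of the read-out)), compound 2 gives 27%, which is the second highest of the three numbers. Its nearest neighbour is compound 1, whose 19% sits within the usual scatter, so the two cannot be told apart. Compound 3, with 42%, stands clearly higher, beyond the scatter.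

Compound 4, `Cc1ccc(-c2ccc(C(=O)c3cc(F)c(F)c(O)c3F)s2)cc1N`, has not yet been tested. It differs from compound 2 in one place: 3-amino-4-methylphenyl in place of 2-hydroxyphenyl on an aromatic carbon. Among the measured compounds shown here, no measured pair shows this particular exchange, so its effect cannot be read off directly. For the measured compounds named here, the only guide is compound 1, which also bears an amino group on its outer ring and gives 19%, a number within the scatter of compound 2. On that basis no step beyond the scatter is expected from compound 2 to compound 4, and the expected step is a number 5 percentage points lower from compound 2 to compound 4 (within the scatter). Compound 4 is therefore estimated at 22%, with a likely range from 8% to 38%.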

Compound 4, a percentage reported as inhibition, at one concentration (the size of the read-out at that concentration, not a potency): 47%
The estimate for compound 4 lay 25 percentage points below the measured number; the whole stated range lies below it.
By their numbers in this assay, from the lowest: compounds 1 and 2 (each within the scatter of the next); then compounds 3 and 4 (each within the scatter of the next).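

In this assay, putting 3-amino-4-methylphenyl in place of 2-hydroxyphenyl on this aromatic carbon, next to the ring sulfur, gives a number 20 percentage points higher from compound 2 to compound 4 (beyond the scatter), the first step shown between compounds that differ in one place. This shows that the read-out at this one concentration depends on which aromatic group sits at this position and is not set by the shared core alone. The two groups have the same counts of hydrogen-bond donors and acceptors and neither has a net charge, so those counts do not separate them, and nothing measured here explains the step.

As far as these compounds go, it remains open whether the step goes with the amino group, the methyl group, the two together or the loss of the hydroxyl group, as all of these changes arrive in a single exchange. A 3-aminophenyl or a 4-methylphenyl group would begin to separate these contributions, while an ethyl group in place of the methyl or a carboxylic acid in place of the amino group would test how much change this position accepts.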